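Pyridin-4-yl for Pyridin-3-yl on the Amide Side Chain

The source may hold more compounds than are shown below. What is called first, only, known or untested is meant among the compounds shown, and "the series" means these compounds.

Compound 2, `Cc1cc(C(=O)NCc2cccnc2)nn1Cc1cc(Cl)ccc1OCc1ccccc1`, is the starting point of this step. In a physicochemical assay for lipophilicity, at pH 7.4 (a lower number here means a more polar compound, a higher number a more lipophilic compound), compound 2 gives > 3.7, which is a limit of the assay and not a number. Among the compounds with values here, its parent, compound 1, `CNC(=O)c1cc(C)n(Cc2cc(Cl)ccc2OCc2ccccc2)n1`, is the only other compound measured. In this assay compound 1 gives > 3.7, also a limit. Within the data shown here, the one measured step, a step that the two limits leave unreadable from compound 1 to compound 2, therefore cannot be read, since (the limit of > 3.7 in this assay, at which 2 of the 2 values shown sit). Compound 3, `Cc1cc(C(=O)NCc2ccncc2)nn1Cc1cc(Cl)ccc1OCc1ccccc1`, differs from compound 2 by pyridin-4-yl in place of pyridin-3-yl on a saturated chain carbon bound to an amide-type nitrogen. Among the measured compounds shown here, no measured step touches a change of this kind, and the single step available is unreadable, so nothing points to a shift in either direction. Compound 3 is expected to show a step that the limit leaves unreadable from compound 2 to compound 3, no step beyond the scatter. Compound 3 is estimated at 3.9, in a range from 3.5 to 4.4.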

Compound 3, distribution coefficient: > 3.7
Compound 3 was reported as a limit; the forecaster's own chance of this, stated with the estimate: 75%; the middle value is on the limit's open side.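

In this assay compound 3 gives > 3.7, a limit of the assay and not a number. No step among compound 1, compound 2 and compound 3 can be read: the limit of > 3.7 in this assay, at which 3 of the 3 values shown sit.

The compounds shown leave open whether pyridin-4-yl and pyridin-3-yl differ at all in this assay.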